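The source may hold more compounds than are shown below. What is called first, only, known or untested is meant among the compounds shown, and "the series" means these compounds.

Three measured compounds share one core: compound 1 `Cc1ccc(-c2cn(C/C=C3\OC(=O)C(OCc4ccccc4)=C3OCc3ccccc3)nn2)cc1`, compound 2 `O=C1O/C(=C\Cn2cc(-c3cc(F)cc(F)c3)nn2)C(OCc2ccccc2)=C1OCc1ccccc1` and compound 3 `COc1ccccc1-c1cn(C[C@H](O)[C@H]2OC(=O)C(OCc3ccccc3)=C2OCc2ccccc2)nn1`. In a functional assay on HeLa cells (Homo sapiens) for antiproliferative activity, read by MTT assay, with a stated time of 72 h (on this read-out lower numbers stand for stronger inhibition and higher numbers for weaker inhibition), compound 1 gives 7480 nM, and compound 2 gives 17700 nM; exchanging 4-methylphenyl for 3,5-difluorophenyl on an aromatic carbon gave a 2.4-fold higher number from compound 1 to compound 2 (0.37 log units; beyond the scatter). Compound 3 reaches only a limit of the assay, > 100000 nM, its value standing at the limit of > 100000 nM in this assay, at which 1 of the 3 values shown sits. Compound 4 `Cc1ccc(-c2cn(C[C@H](O)[C@H]3OC(=O)C(OCc4ccccc4)=C3OCc3ccccc3)nn2)cc1`, not yet measured, differs from compound 3 by 4-methylphenyl in place of 2-methoxyphenyl on an aromatic carbon. Among the measured compounds shown here, the one measured step bearing on an aryl exchange, a 2.4-fold higher number from compound 1 to compound 2 (0.37 log units; beyond the scatter), was of modest size, so at most a modest shift is expected from a number no higher from compound 3 to compound 4 (the limit leaves the size open), with no clear direction. Compound 4 is therefore estimated at 100000 nM, within 30000 nM to 300000 nM, with a fair chance that the assay again reports only a limit.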

Compound 4, half-maximal inhibitory concentration: 25500 nM
Estimate against measurement, compound 4: 3.9-fold (0.59 log units) above; the measured number lies below the stated range.
By their numbers in this assay, from the lowest: compound 1; then compounds 2 and 4 (each within the scatter of the next). At a limit, above all of these: compound 3.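

On the aromatic carbon of the five-membered aromatic ring with 3 nitrogen, the aryl group can decide whether a compound with this hydroxyl-bearing chain gives a number at all in this assay: the exchange of 2-methoxyphenyl for 4-methylphenyl gave an at least 3.9-fold lower number from compound 3 to compound 4 (0.59 log units; beyond the scatter). This step shows a change at this position that is at least modest, but its true size stays unknown, as compound 3 stands at a limit: the limit of > 100000 nM in this assay, at which 1 of the 4 values shown sits.

The compounds shown do not separate the loss of methoxy from the entry of methyl. On these data alone, how an amine or a carboxylic acid on this aryl ring would read remains open.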